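The source may hold more compounds than are shown below. What is called first, only, known or untested is meant among the compounds shown, and "the series" means these compounds.

Working notes on the series.

Compound 1 `Cc1nc(S(C)(=O)=O)ccc1Oc1ncnc(OC2CCN(C(=O)OC(C)C)CC2)c1F` in a functional assay on isolated protein for inhibition of Glucose-dependent insulinotropic receptor (Rattus norvegicus), read by HTRF and cAMP accumulation (a higher number here means that more compound is needed for the effect, a lower number that less compound is needed), gives 142 nM. Among the two measured numbers this is the highest; the only other measured member, compound 2 `Cc1nc(S(C)(=O)=O)ccc1Oc1ncnc(OC2CCN(C(=O)OC(C)(C)C(F)(F)F)CC2)c1F`, gives 47.2 nM, and the step of a 3.0-fold lower number from compound 1 to compound 2 (0.48 log units; beyond the scatter) is the sole measured change in the set. That step alters only the group on the ring nitrogen of the shared core, and it shows that substitution at this position can move the read-out by a modest amount.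

Compound 3 `Cc1nc(S(C)(=O)=O)ccc1Oc1ncnc(OC2CCN(C(=S)OC3(C)CC3)CC2)c1F` is not yet measured. It differs from compound 1 by a group of 7 heavy atoms (5 carbon, 1 oxygen, 1 sulfur; one three-membered non-aromatic ring of carbon only) in place of a group of 6 heavy atoms (4 carbon, 2 oxygen; no ring), on an amine nitrogen in a ring. The step from compound 1 to compound 2 bears on it only loosely, since both changes touch the group on the same ring nitrogen but compound 3 exchanges the whole group rather than one carbon substituent. Among the measured compounds shown here, no measured pair shows this exchange. The expectation for compound 3 is therefore a small step, if any, with the direction uncertain: a 1.4-fold lower number from compound 1 to compound 3 (0.15 log units; within the scatter). The estimated value for compound 3 is 100 nM, within a range of 30 nM to 330 nM.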

Compound 3, half-maximal effective concentration: 48.8 nM
The estimate for compound 3 lay 2.0-fold (0.31 log units) above the measured number; measured number inside the range.
By their numbers in this assay, from the lowest: compounds 2 and 3 (each within the scatter of the next); then compound 1.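

In this assay, exchanging the whole isopropoxycarbonyl group on the amine nitrogen in a ring, rather than adding one substituent to it, gives a 2.9-fold lower number from compound 1 to compound 3 (0.46 log units; beyond the scatter), so the read-out at this position responds to a second, differently built group and not only to the trifluoromethyl change seen earlier. The comparison with the fluorinated group gives a 1.0-fold higher number from compound 2 to compound 3 (0.01 log units; within the scatter), which places two groups with different atoms, one with three fluorine atoms and no ring and the other with sulfur and a three-membered ring of carbon only, within the scatter of each other; among these three compounds, fluorine is therefore not required for the lower number. The material at hand offers nothing that explains either step.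

From the compounds shown here alone, compound 3 brings in sulfur and the three-membered ring in a single exchange, so the share of each in the step remains open, and the counterpart of compound 3 with oxygen in place of sulfur would separate them. Also open, going by these compounds, is how the read-out at this nitrogen responds to quite different groups, such as an amide carbonyl bearing a longer chain or a group carrying an amine.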